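Swapping trifluoromethyl for trifluoromethoxy on two related cores

A few compounds are considered here, and "the series" means these few. Any claim that something is new, unique, unknown or untested is made for them only; others in the source may bear on it.

Compound 1 `CC(O)(CSc1ccccc1C(F)(F)F)C(=O)Nc1ccc(S(F)(F)(F)(F)F)cc1` and compound 2 `CC(O)(CSc1ccccc1OC(F)(F)F)C(=O)Nc1ccc(S(F)(F)(F)(F)F)cc1` differ in one place only. In a functional assay on LNCaP cells (Homo sapiens) for antiproliferative activity, read by propidium iodide staining, with a stated time of 96 h (on this read-out lower numbers stand for stronger inhibition and higher numbers for weaker inhibition), compound 1 gives 12300 nM, and compound 2 gives 10600 nM. The change between them is trifluoromethoxy in place of trifluoromethyl on an aromatic carbon, and it made a step of a 1.2-fold lower number from compound 1 to compound 2 (0.06 log units; within the scatter).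

Compound 3 `CC(O)(CSc1cccc(C(F)(F)F)c1)C(=O)Nc1cccc(S(F)(F)(F)(F)F)c1` carries the same trifluoromethyl group as compound 1 but on a different core; the difference between the two cores is not broken down here. In this assay compound 3 gives 12700 nM, a number that lies within the usual scatter of both compound 1 and compound 2, so no order among the three can be read from these values.

Compound 4 `CC(O)(CSc1cccc(OC(F)(F)F)c1)C(=O)Nc1cccc(S(F)(F)(F)(F)F)c1` has not yet been measured. It stands to compound 3 as compound 2 stands to compound 1: the change is trifluoromethoxy in place of trifluoromethyl on an aromatic carbon. Among the measured compounds shown here, this is the same kind of change as the one from compound 1 to compound 2, but not the same one, since the surroundings of the place differ: in the first pair the group sits ortho to a large group, in the second pair meta to a large group.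

In this assay the expected step is a 1.2-fold lower number from compound 3 to compound 4 (0.06 log units; within the scatter). This expectation rests on the earlier step of a 1.2-fold lower number from compound 1 to compound 2 (0.06 log units; within the scatter), which lay within the scatter, and on the core difference remaining unbroken down, so little shift is expected. Compound 4 is therefore estimated at 11000 nM in this assay, with a range from 6000 nM to 20000 nM.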

Compound 4, half-maximal inhibitory concentration: 10900 nM
Beside the measured number, compound 4's estimate is 1.0-fold (0.00 log units) above it; the range from low to high includes it.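

On the core of compound 3, trifluoromethoxy in place of trifluoromethyl gives a 1.2-fold lower number from compound 3 to compound 4 (0.07 log units; within the scatter) in this assay, and this step agrees with the one seen on the core of compound 1: the same change on two cores in this assay, a 1.2-fold lower number (0.06 log units; within the scatter) from compound 1 to compound 2 and a 1.2-fold lower number (0.07 log units; within the scatter) from compound 3 to compound 4, 1.0-fold (0.00 log units) apart, within the scatter of two such steps For these two pairs, then, the change carries across the two cores in a simple sense: on each core, the step it makes stays within the usual scatter of repeated measurements. This does not show that the two groups can be exchanged freely throughout the series, and it does not explain why the steps are so small, since a change with no readable effect on either core gives little test of whether a real effect would transfer.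

What the compounds shown leave open is whether a group of a different kind in the same place, such as a nitrile, an amine or a carboxylic acid, would make a step beyond the scatter on either core. They also leave open whether the agreement between the two cores would hold for such a group, or on a core in which the sulfur link is replaced by an oxygen atom.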